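This account rests on a few compounds, and the source may have more. Where it says the series, first, only, none or still open, it means among the compounds named here.

Compound 1 `CC(C)(C)n1cc2c(n1)C(=O)CC1(CCN(C(=O)c3cc(-c4ccc(Br)cc4)nc4ccccc34)CC1)O2` gives 820 nM in a functional assay on HepG2 cells (Homo sapiens) for inhibition, read by MTT assay, with a stated time of 72 h (a higher number here means a weaker inhibitor, a lower number a stronger inhibitor), the lowest of the three numbers recorded so far. Compound 2 `COc1ccc(-c2cc(C(=O)N3CCC4(CC3)CC(=O)c3nn(C(C)(C)C)cc3O4)c3ccccc3n2)cc1` gives 2780 nM in this assay, and compound 3 `CC(C)(C)n1cc2c(n1)C(=O)CC1(CCN(C(=O)c3cc(N4CCNCC4)nc4ccccc34)CC1)O2` gives 8570 nM. Each of the two measured changes at the same aromatic carbon of the shared core raised the number: a 3.4-fold higher number from compound 1 to compound 2 (0.53 log units; beyond the scatter) and a 10-fold higher number from compound 1 to compound 3 (1.02 log units; beyond the scatter), while a 3.1-fold higher number from compound 2 to compound 3 (0.49 log units; beyond the scatter) separates the two substituted analogues.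

Compound 4 `CC(C)Oc1cc(C(=O)N2CCC3(CC2)CC(=O)c2nn(C(C)(C)C)cc2O3)c2ccccc2n1` has not yet been measured. It differs from compound 1 by isopropoxy in place of 4-bromophenyl on an aromatic carbon. Both measured steps bear on it, as both swap the same group at the same carbon, and the replacement that removed the aryl ring altogether gave the larger loss, a 10-fold higher number from compound 1 to compound 3 (1.02 log units; beyond the scatter). Isopropoxy likewise carries no ring, so a loss of similar order is expected in this assay, in the direction of a higher number. Compound 4 is therefore estimated at 5000 nM, with a range of 1500 nM to 15000 nM, which means an expected step of a 6.1-fold higher number from compound 1 to compound 4 (0.79 log units; beyond the scatter).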

Compound 4, half-maximal inhibitory concentration: 3150 nM
For compound 4 the middle estimate is 1.6-fold (0.20 log units) above the measured one; the range from low to high includes it.
By their numbers in this assay, from the lowest: compound 1; then compounds 2 and 4 (each within the scatter of the next); then compound 3.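

Leaving the aryl ring off this carbon does not settle the outcome in this assay: replacing 4-bromophenyl with isopropoxy gives a 3.8-fold higher number from compound 1 to compound 4 (0.58 log units; beyond the scatter) and replacing piperazin-1-yl with isopropoxy gives a 2.7-fold lower number from compound 3 to compound 4 (0.43 log units; beyond the scatter) so the two groups without an aryl ring are not equivalent here. Compound 4 also stands level with an aryl-bearing analogue, with a 1.1-fold higher number from compound 2 to compound 4 (0.05 log units; within the scatter) and a difference within the scatter, so compound 2 goes against any simple rule that an aryl ring at this carbon gives the lower number. Nothing available explains these differences.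

The compounds shown leave open whether the lower number of compound 1 depends on its bromine, which unsubstituted phenyl or 4-chlorophenyl at this carbon would address. They also leave open how a smaller ether such as methoxy, a longer alkoxy chain or an open-chain amine would compare with isopropoxy.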